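The compounds below may be only part of what the source reports. "The series", "measured", "known", "first", "only" and "open" are said of these compounds alone.

For the measured compounds named here, in an assay on DDT1 cells (Cricetulus griseus) for binding affinity to adenosine receptor A1 (Homo sapiens), read by radioligand binding (on this read-out higher numbers stand for weaker inhibition and lower numbers for stronger inhibition), compound 3 `O=C(NCc1ccccc1)OC[C@H]1OC(n2cnc3c(NC4CCOC4)ncnc32)[C@H](O)[C@@H]1O` gives 1830 nM, the highest of the three numbers measured so far. Compound 1 `CCCCNC(=O)OC[C@H]1OC(n2cnc3c(NC4CCOC4)ncnc32)[C@H](O)[C@@H]1O` gives 1410 nM and compound 2 `O=C(NC1CC1)OC[C@H]1OC(n2cnc3c(NC4CCOC4)ncnc32)[C@H](O)[C@@H]1O` gives 209 nM; there is a 1.3-fold higher number from compound 1 to compound 3 (0.11 log units; within the scatter), while there is an 8.8-fold higher number from compound 2 to compound 3 (0.94 log units; beyond the scatter). Compound 4 `CN(C)C(=S)OC[C@H]1OC(n2cnc3c(NC4CCOC4)ncnc32)[C@H](O)[C@@H]1O` carries a group of 5 heavy atoms (3 carbon, 1 nitrogen, 1 sulfur; no ring) in place of a group of 10 heavy atoms (8 carbon, 1 nitrogen, 1 oxygen; one six-membered aromatic ring of carbon only), on an oxygen on a saturated carbon. Going by the values given here, no measured step mirrors this change directly: the known steps only vary the substituent on the amide-type nitrogen, and a 6.7-fold lower number from compound 1 to compound 2 (0.83 log units; beyond the scatter) shows that such variation can move the number modestly, whereas a 1.3-fold higher number from compound 1 to compound 3 (0.11 log units; within the scatter) shows it can also stay within the scatter. With the thiocarbamate untested, compound 4 is expected to give 1500 nM, in a wide range from 300 nM to 7000 nM, which would mean a 1.2-fold lower number from compound 3 to compound 4 (0.09 log units; within the scatter).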

Compound 4, inhibition constant: 205 nM
Estimate against measurement, compound 4: 7.3-fold (0.86 log units) above, and the stated range ends above it.
By their numbers in this assay, from the lowest: compounds 4 and 2 (each within the scatter of the next); then compounds 1 and 3 (each within the scatter of the next).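

A group with no hydrogen-bond donor and a sulfur can sit on this oxygen on a saturated carbon without losing ground to the carbamates: there is an 8.9-fold lower number from compound 3 to compound 4 (0.95 log units; beyond the scatter) and a 6.9-fold lower number from compound 1 to compound 4 (0.84 log units; beyond the scatter), while a 1.0-fold lower number from compound 2 to compound 4 (0.01 log units; within the scatter), so these two cannot be told apart. Nothing at hand explains these steps. Going by these compounds, whether the sulfur or the two methyl groups on nitrogen carry the change stays open, as the group changes in both at once. A dimethylcarbamoyl group, with oxygen in place of sulfur, would separate the two.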